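The source may report more compounds than this note shows. Statements on the series, on what has been measured and on what is new or still open speak of the compounds shown alone.

Compound 1 `O=S(=O)(NCC1CCN(CCCc2c[nH]c3ccc(-n4cnnc4)cc23)CC1)c1ccccc1` is the point of departure. In an assay on CHO cells for agonist activity at 5-hydroxytryptamine receptor 1D (Homo sapiens), read by GTPgammaS binding (a lower number here means that less compound is needed, a higher number that more compound is needed for the effect), compound 1 gives 12 nM, the higher of the two numbers recorded so far. Within the data shown here, compound 2 `CC(C)=CCN(C)C1CCN(CCCc2c[nH]c3ccc(-n4cnnc4)cc23)CC1` gives 1.8 nM in this assay, so the step of a 6.7-fold lower number from compound 1 to compound 2 (0.82 log units; beyond the scatter) is the only measured comparison available.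

Compound 3 `CC(CO)(NC1CCN(CCCc2c[nH]c3ccc(-n4cnnc4)cc23)CC1)c1ccccc1` has not yet been measured. Its change from compound 1 is (1-(hydroxymethyl)-1-phenylethyl)amino in place of ((phenylsulfonyl)amino)methyl on a saturated ring carbon. Among the measured compounds shown here, the one measured step that bears on this is the replacement at the same saturated ring carbon, which gave a 6.7-fold lower number from compound 1 to compound 2 (0.82 log units; beyond the scatter): a methyl(3-methylbut-2-en-1-yl)amino group in place of the ((phenylsulfonyl)amino)methyl group. Compound 3 again puts a nitrogen-bearing group there, so a lower number than compound 1 is expected, likely of similar or somewhat smaller size than the step to compound 2, which would mean a 2.4-fold lower number from compound 1 to compound 3 (0.38 log units; beyond the scatter). Compound 3 is therefore estimated at 5 nM, with a range from 1.5 nM to 16 nM.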

Compound 3, half-maximal effective concentration: 3.4 nM
Beside the measured number, compound 3's estimate is 1.5-fold (0.17 log units) above it; the measured number falls inside the stated range.
By their numbers in this assay, from the lowest: compounds 2 and 3 (each within the scatter of the next); then compound 1.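

At the saturated ring carbon, three ring bonds from the ring nitrogen, a second replacement of ((phenylsulfonyl)amino)methyl also gives a lower number in this assay, with a 3.5-fold lower number from compound 1 to compound 3 (0.55 log units; beyond the scatter). The two entering amino groups cannot be told apart, since (1-(hydroxymethyl)-1-phenylethyl)amino in place of methyl(3-methylbut-2-en-1-yl)amino gives a 1.9-fold higher number from compound 2 to compound 3 (0.28 log units; within the scatter), so the effect at this position does not depend on one particular amino substituent, and a six-membered aromatic ring of carbon only is compatible with the lower number. Nothing available here accounts for these differences.

On these data alone, it remains open whether a methyl or a carboxylic acid in place of the hydroxymethyl would keep the number in this assay. Also open, as far as these compounds go, is how a ((phenylsulfonyl)amino) group without its methyl would compare.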